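Bromo analogue of compound 1 in the MCF7 cytotoxicity series

The source may report more compounds than this note shows. Statements on the series, on what has been measured and on what is new or still open speak of the compounds shown alone.

Measured compounds:
- compound 1, `C=C1C(=O)[C@]23C[C@@]1(O)CC[C@H]2c1ccc(O)c(C)c1[C@@H]3Cn1cc(-c2ccccc2)nn1`, in a functional assay on MCF7 cells (Homo sapiens) for cytotoxicity, read by MTT assay, with a stated time of 4 days (on this read-out higher numbers stand for weaker inhibition and lower numbers for stronger inhibition), gives 1740 nM.
- compound 2, `C=C1C[C@]23C[C@@]1(O)CC[C@@H]2c1cccc(C)c1[C@@H]3Cn1cc(-c2ccc(Cl)cc2)nn1`, in this assay reaches only the limit > 20000 nM.
- compound 3, `C=C1C[C@]23C[C@@]1(O)CC[C@@H]2c1cccc(C)c1[C@@H]3Cn1cc(-c2ccccn2)nn1`, in this assay likewise reaches only the limit > 20000 nM.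

Going by the values given here, compound 1 is the only member of the set with a number; the other two values are limits. Compounds 2 and 3 also differ from compound 1 in the core, lacking its ketone and phenol, so the change from compound 2 to compound 3, a step that the two limits leave unreadable from compound 2 to compound 3, cannot be read as a step and bears only loosely on what follows. The evidence here is confined to the limit of > 20000 nM in this assay, at which 2 of the 3 values shown sit.

Compound 4, `C=C1C(=O)[C@]23C[C@@]1(O)CC[C@H]2c1ccc(O)c(C)c1[C@@H]3Cn1cc(-c2ccc(Br)cc2)nn1`, differs from compound 1 by bromo in place of hydrogen on an aromatic carbon. Among the compounds with values here, no measured pair isolates a halogen on the phenyl of the triazole within the core of compound 1; the 4-chlorophenyl of compound 2 sits on the other core and at the limit, which does not transfer. The step from compound 1 to compound 4 is therefore expected to be small, a 1.4-fold higher number from compound 1 to compound 4 (0.16 log units; within the scatter), not clearly beyond the scatter in either direction. Compound 4 is estimated at 2500 nM, with a range from 800 nM to 10000 nM.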

Compound 4, half-maximal inhibitory concentration: 270 nM
Compound 4: middle estimate off by 9.3-fold (0.97 log units), on the high side, outside the stated range (below it).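

In this assay, the change from phenyl to 4-bromophenyl gives a 6.4-fold lower number from compound 1 to compound 4 (0.81 log units; beyond the scatter) and so shows that this position, on an aromatic carbon para to a large group, responds to substitution within the shared core. The earlier compounds shown here could not show this, as they offered no pair within that core that isolated a substituent on this phenyl. The result also shows that a readable step can come from a group that brings no ring, no hydrogen-bond donors or acceptors and no net charge.

Whether the step is specific to bromo remains open, since the compounds shown do not include the same core with chloro, methoxy, trifluoromethyl, an amine or a carboxylic acid at this position, and they do not show whether the lower number would persist with any of these groups. None of the values shown bears on why bromo in place of hydrogen gives this step, and the limits on the other core offer no explanation for it.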